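The source may hold more compounds than are shown below. What is called first, only, known or untested is meant among the compounds shown, and "the series" means these compounds.

Within the data shown here, in a physicochemical assay for lipophilicity (a higher number here means a more lipophilic compound, a lower number a more polar compound), only two compounds have numbers so far. Compound 1 (`O=C(OCc1ccc([N+](=O)[O-])cc1)c1cnccn1`) gives 0.99, while compound 2 (`CC(=O)Oc1ccc(COC(=O)c2ccccc2)cc1`) gives 3.38. Compound 2 therefore stands as the higher of the two, and the gap between them lies beyond the scatter of repeated measurements. The two differ in more than one place, so their gap does not isolate any single structural change.

The next compound, compound 3 (`CC(=O)OCc1ccc(OC(C)=O)cc1`), has not yet been measured. It has methyl in place of phenyl on a carbonyl carbon. Among the measured compounds shown here, no measured pair shows this change, so the expectation rests on the structural change alone. A fall in this assay beyond the scatter is expected. The estimated step is a number 1.68 log units lower from compound 2 to compound 3 (beyond the scatter). For compound 3 the estimated value is 1.7, with an expected range from 1.3 to 2.1.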

Compound 3, partition coefficient: 2.03
The estimate for compound 3 lay 0.33 log units below the measured number; low and high end bracket the measured number.
By their numbers in this assay, from the lowest: compound 1; then compound 3; then compound 2.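

In this assay, among these compounds, putting methyl in place of phenyl on a carbonyl carbon gives a number 1.35 log units lower from compound 2 to compound 3 (beyond the scatter), the first step here that isolates a single structural change. This position therefore responds strongly to the change, whereas the gap between compound 1 and compound 2 could not be tied to any one place. Nothing available explains why the number moves in this way.

This single pair cannot show whether a step of this size would recur on another core, such as the core of compound 1. It also leaves open what lies between and beyond these two groups at this carbonyl carbon, where an ethyl group, a longer chain or an amine would each give a further reading.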